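Chloro to Hydroxy on a Pyrimidine Anti-Inflammatory Series

A few compounds are considered here, and "the series" means these few. Any claim that something is new, unique, unknown or untested is made for them only; others in the source may bear on it.

Measured compounds:
Compound 1 `N#Cc1c(Nc2ccc(Cl)cc2)nc(SCC(=O)Nn2c(COc3ccc(Cl)cc3Cl)nc3ccccc3c2=O)nc1-c1ccccc1`: 54.6%
Compound 2 `N#Cc1c(Nc2ccc(O)cc2)nc(SCC(=O)Nn2c(COc3ccc(Cl)cc3Cl)nc3ccccc3c2=O)nc1-c1ccccc1`: 72.7%
Compound 3 `N#Cc1c(Nc2ccccc2)nc(SCC(=O)Nn2c(COc3ccc(Cl)cc3Cl)nc3ccccc3c2=O)nc1-c1ccc(Cl)cc1`: 43.6%

In a functional assay on the whole organism (strain albino) for inhibition, with Rattus norvegicus as the target, read by paw edema, with a stated time of 1 h, at a dose of 100 mg/kg by the oral route (on this read-out lower numbers stand for less inhibition and higher numbers for more inhibition at the one dose given (going by the name of the read-out)), compound 2 gives the highest of the three numbers. The change from compound 1 to compound 2 is hydroxy in place of chloro on an aromatic carbon, and it made the step of a number 18.1 percentage points higher from compound 1 to compound 2 (beyond the scatter). Compound 3 has the same atoms as compound 1 joined differently; the difference between the two cores is not broken down here. Compound 4 `N#Cc1c(Nc2ccccc2)nc(SCC(=O)Nn2c(COc3ccc(Cl)cc3Cl)nc3ccccc3c2=O)nc1-c1ccc(O)cc1` is not yet measured. Compound 4 differs from compound 3 by hydroxy in place of chloro on an aromatic carbon, the same change seen between compound 1 and compound 2, though here the further reading is 4-chlorophenyl to 4-hydroxyphenyl only. An upward step is expected for compound 4, somewhat smaller than the earlier one, because a number 18.1 percentage points higher from compound 1 to compound 2 (beyond the scatter) sits on a different ring. The expected step is a number 12.4 percentage points higher from compound 3 to compound 4 (beyond the scatter). Compound 4 is therefore estimated at 56%, with a likely range from 42% to 70%.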

Compound 4, a percentage reported as inhibition, in the whole organism at one dose (the size of the read-out at that dose, not a potency): 90.9%
Estimate against measurement, compound 4: 34.9 percentage points below, and the stated range ends below it.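

In this assay, hydroxy in place of chloro on an aromatic carbon again goes with more inhibition, this time with a number 47.3 percentage points higher from compound 3 to compound 4 (beyond the scatter). The direction of the change carries over between these two cores, but its size does not: the same change on two cores in this assay, a number 18.1 percentage points higher (beyond the scatter) from compound 1 to compound 2 and a number 47.3 percentage points higher (beyond the scatter) from compound 3 to compound 4, 29.2 percentage points apart, beyond the scatter of two such steps. So a step measured on one core cannot be carried to the other as a fixed amount, and these two pairs do not show why the sizes differ or whether the direction would hold on any further core.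

The compounds shown leave open whether an amine or a methoxy group in place of the chloro would give a step like that of hydroxy. They also leave open what a hydroxy on both aromatic rings would give.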